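Amine side chain change on the shared core

A few compounds are considered here, and "the series" means these few. Any claim that something is new, unique, unknown or untested is made for them only; others in the source may bear on it.

compound 1: `CCC(COC)N(C)c1nc(C)nc2c1nnn2-c1ccc(C(C)C)cc1Br` — 11.2 nM
compound 2: `CCCC(C)Nc1nc(C)nc2c1nnn2-c1c(C)cc(C)cc1C` — 7.1 nM

In an in vitro assay on 293-EBNA cells for binding affinity to corticotropin-releasing factor receptor 1 (Homo sapiens) (on this read-out lower numbers stand for stronger inhibition and higher numbers for weaker inhibition), compound 1 gives 11.2 nM, the higher of the two numbers, and compound 2 gives 7.1 nM; the two lie within the scatter of each other. Compound 3 `CCCCC(CCCC)Nc1nc(C)nc2c1nnn2-c1ccc(C(C)C)cc1Br` differs from compound 1 by a group of 10 heavy atoms (9 carbon, 1 nitrogen; no ring) in place of a group of 8 heavy atoms (6 carbon, 1 nitrogen, 1 oxygen; no ring), on an aromatic carbon. Among the measured compounds shown here, no comparable step between measured compounds is available. Since compound 2, whose entering-type group also carries one hydrogen-bond donor, sits within the scatter of compound 1, the step is expected to stay within the scatter: a 1.2-fold lower number from compound 1 to compound 3 (0.09 log units; within the scatter). For compound 3 the estimate in this assay is 9 nM, with a range of 3 nM to 27 nM.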

Compound 3, inhibition constant: 4.5 nM
Compound 3: middle estimate off by 2.0-fold (0.30 log units), on the high side; low and high end bracket the measured number.
By their numbers in this assay, from the lowest: compounds 3, 2 and 1 (each within the scatter of the next, the first and the last beyond it).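

In this assay, the position on an aromatic carbon next to the ring nitrogen now has its first readable step: the group of 10 heavy atoms in place of the group of 8 heavy atoms gives a 2.5-fold lower number from compound 1 to compound 3 (0.40 log units; beyond the scatter), a modest change. The position therefore accepts this longer, oxygen-free group with a hydrogen-bond donor without losing binding. No measurement on hand explains the step.

The change alters several features at once, so their separate contributions remain unresolved. As far as these compounds go, a morpholine or a cyclopropylmethylamine at this position remains open.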